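The source may report more compounds than this note shows. Statements on the series, on what has been measured and on what is new or still open speak of the compounds shown alone.

Series notes. The shared core is carried by compound 1 `Nc1nc(N2CCCC2)c2ncn(/C=C3/CC3(CO)CO)c2n1`, compound 2 `Nc1nc(SC2CCCC2)c2ncn(/C=C3/CC3(CO)CO)c2n1` and compound 3 `CCCCCCOc1nc(N)nc2c1ncn2/C=C1/CC1(CO)CO`; compound 4 `CCCCSc1nc(N)nc2c1ncn2/C=C1/CC1(CO)CO` has not yet been measured. In an ADME assay on BCBL1 cells (Homo sapiens) for cytotoxicity, with a stated time of 7 days (a higher number here means that more compound is tolerated, a lower number that less compound is tolerated), compound 1 gives > 20000 nM, which is a limit of the assay and not a number. Compound 2 also sits at a limit, giving > 20000 nM in this assay. Compound 3 likewise returns a limit, > 20000 nM. Compound 1 therefore stands where every measured member of the series stands, at the limit, and no order among the three can be read. Within the data shown here, the three measured steps, a step that the two limits leave unreadable from compound 1 to compound 2, a step that the two limits leave unreadable from compound 1 to compound 3 and a step that the two limits leave unreadable from compound 2 to compound 3, are all unreadable; the only evidence available is the limit of > 20000 nM in this assay, at which 3 of the 3 values shown sit.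

The change to compound 4 is butylsulfanyl in place of pyrrolidin-1-yl on an aromatic carbon. The step from compound 1 to compound 2 already replaced pyrrolidin-1-yl with cyclopentylsulfanyl on an aromatic carbon and left compound 2 at the limit, so no readable step bears on the new change. No step beyond the scatter in this assay is expected in either direction; the expected result is another limit. The step expected is a step that the limit leaves unreadable from compound 1 to compound 4. Compound 4 is estimated at 25000 nM, with a range from 15000 nM to 60000 nM.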

Compound 4, half-maximal cytotoxic concentration: > 20000 nM
Compound 4: only a limit was reported; the forecaster's own chance of this, stated with the estimate: 85%; the middle value lies beyond the limit too.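

Compound 4 also returns a limit and not a number, so its steps from compound 1, compound 2 and compound 3 cannot be read. The compounds shown leave open at what concentration any of them becomes cytotoxic in this assay, and whether the substituents differ at all, with only this to go on: the limit of > 20000 nM in this assay, at which 4 of the 4 values shown sit.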